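A Piperidine Carboxamide Replaces the Piperazine Sulfonamide

The source may report more compounds than this note shows. Statements on the series, on what has been measured and on what is new or still open speak of the compounds shown alone.

Going by the values given here, compound 2, `O=S(=O)(c1ccc([C@H]2CC[C@]3(CC2)OOC2(O3)C3CC4CC(C3)CC2C4)cc1)N1CCNCC1`, gives 16 mL.min-1.g-1 in an ADME assay on microsomes from liver (Homo sapiens) for metabolic stability, read by LC-MS, tested at 1 uM (a lower number here means slower removal, a higher number faster removal of the compound), and it is the only compound with a number rather than a limit in this assay. Compound 1, `N[C@H]1CC[C@@H](Oc2ccc([C@H]3CC[C@]4(CC3)OOC3(O4)C4CC5CC(C4)CC3C5)cc2)CC1`, sits at the limit of this assay with < 7 mL.min-1.g-1. Among the compounds with values here, the one measured step is an at least 2.2-fold higher number from compound 1 to compound 2 (0.35 log units; beyond the scatter), and its size is known only as a lower bound because of the limit of < 7 mL.min-1.g-1 in this assay, at which 1 of the 2 values shown sits.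

Compound 3, `NC(=O)C1CCN(Cc2ccc([C@H]3CC[C@]4(CC3)OOC3(O4)C4CC5CC(C4)CC3C5)cc2)CC1`, differs from compound 2 in one place: (4-carbamoylpiperidin-1-yl)methyl in place of (piperazin-1-yl)sulfonyl on an aromatic carbon. The change sits where the measured step also acted, but neither of the groups it exchanges took part in that step, so it gives only a loose guide: a change at this position can shift the number in this assay by at least a modest amount. Compound 3 is therefore expected to give 20 mL.min-1.g-1 in this assay, between 8 mL.min-1.g-1 and 50 mL.min-1.g-1, a step of a 1.3-fold higher number from compound 2 to compound 3 (0.10 log units; within the scatter), with no firm direction.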

Compound 3, intrinsic clearance in microsomes: 10 mL.min-1.g-1
Estimate against measurement, compound 3: 2.0-fold (0.30 log units) above, within the range that was stated.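

In this assay, the exchange on this aromatic carbon gives a 1.6-fold lower number from compound 2 to compound 3 (0.20 log units; within the scatter), so (4-carbamoylpiperidin-1-yl)methyl can take the place of (piperazin-1-yl)sulfonyl with no difference beyond the scatter. The earlier step showed that a change at this position can move the number, and this one shows that not every exchange here does. Set against (4-aminocyclohexyl)oxy, the same group gives an at least 1.4-fold higher number from compound 1 to compound 3 (0.15 log units; that floor lies within the scatter), and this floor does not establish a real gap, because one of the two values is a limit: the limit of < 7 mL.min-1.g-1 in this assay, at which 1 of the 3 values shown sits.

The compounds shown leave open how the number in this assay responds to a carboxylic acid or a nitrile in place of the carbamoyl on the piperidine ring. They also do not separate the effect of the link from that of the ring, which a (piperazin-1-yl)methyl group would do.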